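A Fluoro Swap on the Amide Aryl Ring

The source may report more compounds than this note shows. Statements on the series, on what has been measured and on what is new or still open speak of the compounds shown alone.

Compound 1 `Cc1cc(=O)n(-c2cccc(F)c2)nc1C(=O)Nc1ccc(Oc2ncnc3ccsc23)cc1` and compound 2 `Cc1cc(=O)n(-c2ccc(F)c(F)c2)nc1C(=O)Nc1ccc(Oc2ncnc3ccsc23)cc1` share one core, while compound 3 `Cc1cc(=O)n(-c2ccccc2C(F)(F)F)nc1C(=O)Nc1ccc(Oc2ncnc3sccc23)cc1` is built on another; the difference between the two cores is not broken down here. In a functional assay on A549 cells (Homo sapiens) for cytotoxicity, read by MTT assay, with a stated time of 72 h (a higher number here means a weaker inhibitor, a lower number a stronger inhibitor), compound 1 gives 9540 nM, compound 2 gives 8180 nM, and compound 3 gives 19900 nM, the highest of the three numbers. The change from compound 1 to compound 2, (fluoro in place of hydrogen on an aromatic carbon), produced the step of a 1.2-fold lower number from compound 1 to compound 2 (0.07 log units; within the scatter).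

Compound 4 `Cc1cc(=O)n(-c2ccccc2C(F)(F)F)nc1C(=O)Nc1ccc(Oc2ncnc3sccc23)c(F)c1` has not yet been measured. It differs from compound 3 by fluoro in place of hydrogen on an aromatic carbon. Going by the values given here, this is the same kind of change as the one from compound 1 to compound 2, but the place is not the same: in compound 2 the fluoro sits ortho to a fluoro group and para to a large group, whereas in compound 4 it sits ortho to a large group and meta to a large group. Because the earlier fluoro step a 1.2-fold lower number from compound 1 to compound 2 (0.07 log units; within the scatter) stayed within the scatter, a step of similar small size is expected here, a 1.2-fold lower number from compound 3 to compound 4 (0.09 log units; within the scatter). Among the compounds with values here, the uncertainty is wider than for that earlier pair: the place differs, and compound 3 stands on a core for which only one number is known. Compound 4 is accordingly estimated at 16000 nM, with a range from 7000 nM to 40000 nM.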

Compound 4, half-maximal inhibitory concentration: 16300 nM
Estimate against measurement, compound 4: 1.0-fold (0.01 log units) below, within the range that was stated.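

In this assay, fluoro in place of hydrogen on an aromatic carbon gave a 1.2-fold lower number from compound 3 to compound 4 (0.09 log units; within the scatter), so on this core too the change left the cytotoxicity reading without a visible shift. Set beside the earlier fluoro step on the other core, this step does not differ from it, and the small size of the step carried over from one core to the other in these two pairs: the same change on two cores in this assay, a 1.2-fold lower number (0.07 log units; within the scatter) from compound 1 to compound 2 and a 1.2-fold lower number (0.09 log units; within the scatter) from compound 3 to compound 4, 1.0-fold (0.02 log units) apart, within the scatter of two such steps. This does not show that the fluoro swap has a shared effect on the two cores, since both steps are too small to be told from repeated measurement, and the two pairs differ in the place of the fluoro as well as in the core, so the part played by the core cannot be separated from the part played by the place, and two pairs say nothing about any further core.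

The compounds shown leave open whether the same fluoro, set in one and the same place on both cores, would again give steps of this size. They also leave open whether a larger change in the place of the fluoro of compound 4, such as an amine or a carboxylic acid, would move the number beyond the scatter.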